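Amide nitrogen substitution in a diaryl acetate series

The source may hold more compounds than are shown below. What is called first, only, known or untested is meant among the compounds shown, and "the series" means these compounds.

Compound 1 `CNC(=O)c1cc(-c2ccc(F)cc2F)ccc1OC(C)=O` is the reference point of this small set. In a functional assay on the whole organism (Ear) for inhibition, with Mus musculus as the target, at a dose of 40 mg/kg by the oral route (a higher number here means more inhibition at the dose given (going by the name of the read-out), a lower number less inhibition), compound 1 gives 48.8%, the highest of the three numbers in hand. Compound 2 `CC(=O)Oc1ccc(-c2ccc(F)cc2F)cc1C(=O)Nc1ccccc1C` carries 2-methylphenyl in place of methyl on the amide-type nitrogen, and in this assay compound 2 gives 19.6%. Compound 3 `CC(=O)Oc1ccc(-c2ccc(F)cc2F)cc1C(=O)Nc1cccc(C)c1` carries 3-methylphenyl at the same place, and in this assay compound 3 gives 12.8%. The steps of a number 29.2 percentage points lower from compound 1 to compound 2 (beyond the scatter) and a number 36 percentage points lower from compound 1 to compound 3 (beyond the scatter) both run downward and beyond the scatter, whereas a number 6.8 percentage points lower from compound 2 to compound 3 (within the scatter) stays within it.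

Compound 4 `CC(=O)Oc1ccc(-c2ccc(F)cc2F)cc1C(=O)NN1CCOCC1` has not yet been measured in this assay. Relative to compound 1 the change is morpholin-4-yl in place of methyl on an amide-type nitrogen. Among the measured compounds shown here, no measured step involves a morpholin-4-yl group. The two steps that bear on this place, a number 29.2 percentage points lower from compound 1 to compound 2 (beyond the scatter) and a number 36 percentage points lower from compound 1 to compound 3 (beyond the scatter), both show that exchanging the methyl on the amide-type nitrogen for a larger group has lowered the number, modestly in one case and largely in the other. The incoming group differs from both methylphenyl groups, so the direction is taken from those steps while the size remains uncertain: the expected step is a number 18.8 percentage points lower from compound 1 to compound 4 (beyond the scatter), downward and beyond the scatter. Compound 4 is therefore estimated at 30%, with a range from 10% to 50%.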

Compound 4, a percentage reported as inhibition, in the whole organism at one dose (the size of the read-out at that dose, not a potency): 0%
Beside the measured number, compound 4's estimate is 30 percentage points above it; measured number below the stated range.
By their numbers in this assay, from the lowest: compound 4; then compounds 3 and 2 (each within the scatter of the next); then compound 1.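

Morpholin-4-yl on the amide-type nitrogen brings this assay to its lowest point in the series, with a number 48.8 percentage points lower from compound 1 to compound 4 (beyond the scatter), and compound 4 gives 0%. The fall is therefore not confined to the two methylphenyl groups: a six-membered non-aromatic ring at this place also lowers the number, and further than either aromatic replacement, with a number 19.6 percentage points lower from compound 2 to compound 4 (beyond the scatter) and a number 12.8 percentage points lower from compound 3 to compound 4 (beyond the scatter), whereas the two methylphenyl compounds remain within the scatter of each other. No measurement on hand accounts for this fall.

The compounds shown leave open whether any replacement for methyl on this nitrogen can hold the number near that of compound 1, since the set includes no small alkyl group such as ethyl, no unsubstituted amide hydrogen and no piperidin-1-yl, which would separate the effect of the morpholine ring oxygen from that of the ring as a whole. With only a single oral dose in hand, the read-out also gives no potency for any of the four compounds and no dose response for compound 4.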